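The source may report more compounds than this note shows. Statements on the series, on what has been measured and on what is new or still open speak of the compounds shown alone.

Measured compounds:
compound 1, `CCCOc1c(C(=O)N(C)Cc2cc(C(F)(F)F)cc(C(F)(F)F)c2)c(=O)n(C)c2ccccc12` — 2100 nM
compound 2, `COc1cc(CN(C)C(=O)c2c(OCCCC3CCN(C(=O)OC(C)(C)C)CC3)c3cnccc3n(C)c2=O)cc(OC)c1` — 1600 nM
compound 3, `COc1cc(CN(C)C(=O)c2c(OCCCC3CCN(C(=O)OC(C)(C)C)CC3)c3cccnc3n(C)c2=O)cc(OC)c1` — 130 nM

In an assay on cells for inhibition of phosphatidylcholine:ceramide cholinephosphotransferase 2 (Homo sapiens), read by mass spectrometry, with stated times of 60 min and 30 min (on this read-out lower numbers stand for stronger inhibition and higher numbers for weaker inhibition), compound 3 stands lowest of the three numbers. Compound 2 sits above it by a gap beyond the usual scatter, and compound 1 further still, so compound 3 is the strongest inhibitor among the measured compounds. Compound 4, `COc1cc(CN(C)C(=O)c2c(OCCCC3CCN(C(=O)OC4(C)CC4)CC3)c3cccnc3n(C)c2=O)cc(OC)c1`, is compound 3 with one change, 1-methylcyclopropyl in place of tert-butyl on an oxygen next to a carbonyl group. For the measured compounds named here, no pair of measured compounds differs by this change alone, so the data give no step to lean on. Both groups are named without donors, acceptors or charge, and the change sits far from the rest of the molecule. On that basis a step of no more than the scatter is expected, in no fixed direction. Compound 4 is therefore expected to give 150 nM, within 50 nM to 450 nM. The expected step from compound 3 to compound 4 is a 1.2-fold higher number from compound 3 to compound 4 (0.06 log units; within the scatter).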

Compound 4, half-maximal inhibitory concentration in the phosphatidylcholine:ceramide cholinephosphotransferase 2 assay: 300 nM
For compound 4 the middle estimate is 2.0-fold (0.30 log units) below the measured one, and the stated range covers the measured number.
By their numbers in the phosphatidylcholine:ceramide cholinephosphotransferase 2 assay, from the lowest: compound 3; then compound 4; then compounds 2 and 1 (each within the scatter of the next).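

The earlier compounds shown here all kept other parts of the molecule in play, so they said nothing about the group on this oxygen next to a carbonyl group. In the phosphatidylcholine:ceramide cholinephosphotransferase 2 assay, the swap of tert-butyl for 1-methylcyclopropyl, each of 4 heavy atoms and neither with hydrogen-bond donors or acceptors, gives a 2.3-fold higher number from compound 3 to compound 4 (0.36 log units; beyond the scatter), so this position does respond to a change of this kind, though only modestly. The same pair also differs in a physicochemical assay for solubility, read by LC-MS, at pH 6.8 (on this read-out higher numbers stand for higher solubility and lower numbers for lower solubility), where compound 3 gives 7.3 ug/mL and compound 4 gives 16 ug/mL, so the weaker inhibitor gives the higher number: the measured solubility of compound 3, 7.3 ug/mL, and of compound 4, 16 ug/mL, a 2.2-fold higher number (0.34 log units; beyond the scatter)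

This is a single pair, and it sets no general rule for the position. Still open, on these data alone, is whether a cyclobutyl or a 1-(trifluoromethyl)cyclopropyl group on the same oxygen, or a free amine in place of the whole tert-butoxycarbonyl group, would hold up on both read-outs.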